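The source may hold more compounds than are shown below. What is called first, only, known or untested is meant among the compounds shown, and "the series" means these compounds.

Working notes on the series. Two compounds of the shared core have numbers in an assay on Cortex for displacement of a labelled ligand from Voltage-dependent L-type calcium channel subunit alpha-1D (Rattus norvegicus); a lower number here means a stronger inhibitor, a higher number a weaker inhibitor. Compound 1 `COC(=O)C1=C(C)N=C(C)/C(=C(/O)OC)C1c1ccccc1OCCO[N+](=O)[O-]` gives 38 nM. Among the measured compounds shown here, compound 2 `COC(=O)C1=C(C)N=C(C)/C(=C(/O)OC)C1c1cccc(OCc2nonc2C)c1` gives 320 nM, the higher of the two numbers; its only neighbour, compound 1, lies beyond the scatter from it. Compound 3 `COC(=O)C1=C(C)N=C(C)/C(=C(/O)OC)C1c1cccc(OCc2c(C(N)=O)no[n+]2[O-])c1` has not been measured. It differs from compound 2 in one place: a group of 9 heavy atoms (3 carbon, 3 nitrogen, 3 oxygen; one five-membered aromatic ring with 3 hetero atoms) in place of a group of 6 heavy atoms (3 carbon, 2 nitrogen, 1 oxygen; one five-membered aromatic ring with 3 hetero atoms), on a saturated chain carbon bound to an oxygen on an aromatic ring. For the measured compounds named here, no step between measured compounds carries this change, so the two measured numbers give no direct guide to its size or direction. The expectation is a step of about a 1.3-fold higher number from compound 2 to compound 3 (0.10 log units; within the scatter) from compound 2 to compound 3, which is within the scatter of repeated measurements. In this assay compound 3 is estimated at 400 nM, with a range from 130 nM to 1200 nM.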

Compound 3, inhibition constant: 1600 nM
The estimate for compound 3 lay 4.0-fold (0.60 log units) below the measured number; measured number above the stated range.
By their numbers in this assay, from the lowest: compound 1; then compound 2; then compound 3.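

At this place, on a saturated chain carbon bound to an oxygen on an aromatic ring, the identity of the group matters in this assay: replacing 4-methyl-1,2,5-oxadiazol-3-yl with the larger entering group gives a 5.0-fold higher number from compound 2 to compound 3 (0.70 log units; beyond the scatter). Among the compounds shown here, this is the first single-place change the series can read, and it runs toward weaker inhibition. Both groups contain a five-membered aromatic ring with 3 hetero atoms, so retaining that ring count does not preserve the number here, and no available measurement bears on the reason for the rise.

The carboxamide and the extra ring oxygen of the entering group arrive together, so the compounds shown do not divide the step between them. From the compounds shown here alone, how a nitrile or a carboxylic acid in place of that carboxamide would read also remains open.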